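Dimethylamino in place of methyl on a sulfonyl sulfur

The source may hold more compounds than are shown below. What is called first, only, known or untested is meant among the compounds shown, and "the series" means these compounds.

Compound 1 `CONC(=O)CCc1ccccc1` gives >= 200000 nM as a limit in a physicochemical assay for solubility, read by LC-MS, in phosphate buffer, measured as kinetic solubility, with a stated time of 24 h, at pH 7.4, tested at 200 uM; a higher number here means a more soluble compound, a lower number a less soluble compound
Compound 2 `CS(=O)(=O)NC(=O)CCc1ccccc1` gives 200000 nM in this assay

Among the compounds with values here, compound 2 stands at 200000 nM and holds the only exact number so far. For compound 1 the reading is the limit of >= 200000 nM in this assay, at which 1 of the 2 values shown sits, and remains a limit. Compound 3 `CN(C)S(=O)(=O)NC(=O)CCc1ccccc1` carries dimethylamino in place of methyl on a sulfonyl sulfur as its change, dimethylamino in place of methyl on a sulfonyl sulfur. Within the data shown here, the only measured step, a number no higher from compound 1 to compound 2 (the limit leaves the size open), lies at another place and leaves its size open. Among the measured compounds shown here, with that step as the sole guide, no shift beyond the usual scatter is expected in this assay here. The estimated change is a 1.1-fold lower number from compound 2 to compound 3 (0.05 log units; within the scatter) and no more. Compound 3 is expected at 180000 nM with an estimated range from 100000 nM to 220000 nM as its upper end.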

Compound 3, solubility: 199000 nM
For compound 3 the middle estimate is 1.1-fold (0.04 log units) below the measured one; low and high end bracket the measured number.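

In this assay, dimethylamino in place of methyl on a sulfonyl sulfur gives a 1.0-fold lower number from compound 2 to compound 3 (0.00 log units; within the scatter). Within the data shown here, this is the first step whose size can be read, and it shows that this sulfur, whose other neighbour is the amide-type nitrogen, carries either group without a shift beyond the scatter. From the compounds shown here alone, whether a morpholine, a carboxylic acid or a longer chain on this sulfur would keep the number there remains open, and so does the size of any step involving compound 1, whose reading remains a limit: the limit of >= 200000 nM in this assay, at which 1 of the 3 values shown sits.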